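The source may report more compounds than this note shows. Statements on the series, on what has been measured and on what is new or still open speak of the compounds shown alone.

Compound 1 `O=C(CSC(=S)N[C@H]1CCOC1=O)Nc1ccc(Cl)cc1`: in a functional assay on SMMC-7721 cells (Homo sapiens) for cytotoxicity, read by MTT assay, with a stated time of 72 h (on this read-out higher numbers stand for weaker inhibition and lower numbers for stronger inhibition), compound 1 gives a value that is a limit of the assay, > 128000 nM. Compound 2 `O=C(CSC(=S)N[C@H]1CCOC1=O)Nc1ccccc1Cl`: in this assay compound 2 gives 49900 nM. Compound 3 `COc1ccc(NC(=O)CSC(=S)N[C@H]2CCOC2=O)cc1`: in this assay compound 3 also gives a limit, > 128000 nM.

Compound 3 thus stands at the limit of this assay, namely (the limit of > 128000 nM in this assay, at which 2 of the 3 values shown sit). Compound 4 `O=C(CSC(=S)N[C@H]1CCOC1=O)Nc1ccc(F)cc1` differs from it by fluoro in place of methoxy on an aromatic carbon. The step most closely related runs between two limits: a step that the two limits leave unreadable from compound 1 to compound 3. For the measured compounds named here, the only readable step, an at least 2.5-fold lower number from compound 1 to compound 2 (0.40 log units; beyond the scatter), concerns a change of position on the ring rather than a swap of group at the same place. With both comparable compounds at the limit, another limit is expected for compound 4, and the expected step is a step that the limit leaves unreadable from compound 3 to compound 4. Compound 4 is therefore estimated at 150000 nM, within 60000 nM to 400000 nM.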

Compound 4, half-maximal inhibitory concentration: > 128000 nM
Compound 4 ended at the assay's limit (the forecaster's own chance of this, stated with the estimate: 70%); the middle value lies beyond the limit too.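

Fluoro at this place, para to a large group, gives compound 4 a limit in this assay, not a number, so the steps among compound 1, compound 3 and compound 4 cannot be read. For the compounds shown here, the one readable step is an at least 2.5-fold higher number from compound 2 to compound 4 (0.40 log units; beyond the scatter), but it changes both the halogen and its place, so neither change alone can be credited with it. Only compound 2 has left the limit that the three other compounds share: the limit of > 128000 nM in this assay, at which 3 of the 4 values shown sit.

Going by these compounds, whether these three compounds differ beyond the limit stays open. So does whether an amine or a carboxylic acid at this place would give a readable value.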